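Series notes: cyano to phenyl on the benzyl arm of compound 1

A few compounds are considered here, and "the series" means these few. Any claim that something is new, unique, unknown or untested is made for them only; others in the source may bear on it.

Compound 1 `COC(=O)[C@H](CCSC)NC(=O)c1ccc(NCc2cncn2Cc2ccc(C#N)cc2)cc1-c1ccccc1` is the reference of this set. In a functional assay on NIH3T3 cells (Mus musculus) (on this read-out lower numbers stand for an effect already at smaller amounts and higher numbers for an effect only at larger amounts of compound), compound 1 gives > 10 uM, which is a limit of the assay and not a number. Compound 2 `CSCNC(=O)c1ccc(NCc2cncn2Cc2ccc(C#N)cc2)cc1-c1ccccc1` also returns only a limit in this assay, > 10 uM. Compound 3 `N#Cc1ccc(Cn2cncc2CNc2ccc(C(=O)NCc3ccccc3)c(-c3ccccc3)c2)cc1` likewise stays at a limit in this assay, > 10 uM. The three steps among them, from compound 1 to compound 2 a step that the two limits leave unreadable from compound 1 to compound 2, from compound 1 to compound 3 a step that the two limits leave unreadable from compound 1 to compound 3 and from compound 2 to compound 3 a step that the two limits leave unreadable from compound 2 to compound 3, therefore carry no readable size, since (the limit of > 10 uM in this assay, at which 3 of the 3 values shown sit).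

Compound 4 `COC(=O)[C@H](CCSC)NC(=O)c1ccc(NCc2cncn2Cc2ccc(-c3ccccc3)cc2)cc1-c1ccccc1` differs from compound 1 by phenyl in place of cyano on an aromatic carbon, sitting on an aromatic carbon of a six-membered aromatic ring of carbon only, para to a large group; cut one bond further out, 4-cyanophenyl becomes 4-phenylphenyl. Going by the values given here, none of the measured steps touches this position; all three concern the amide-type nitrogen, and all of them are unreadable. Among the compounds with values here, no measured step bears on the change, so no direction can be drawn from the series, and the expected step that the limit leaves unreadable from compound 1 to compound 4 rests on the limit of compound 1 alone. Compound 4 is therefore estimated at 15 uM in this assay, within a range from 3 uM to 60 uM, with a strong chance that only a limit is reported again.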

Compound 4, concentration for half-maximal effect: > 10 uM
Compound 4: only a limit was reported; the forecaster's own chance of this, stated with the estimate: 70%; the middle value does not contradict the limit.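

In this assay compound 4 gives > 10 uM, again a limit of the assay and not a number, so no step from compound 1 to compound 4 can be read: the limit of > 10 uM in this assay, at which 4 of the 4 values shown sit.

The compounds shown leave open whether phenyl in place of cyano, or any change on the amide-type nitrogen, alters the effect in this assay at all.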